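Adding a butylcarbamoyl group to compound 1

A few compounds are considered here, and "the series" means these few. Any claim that something is new, unique, unknown or untested is made for them only; others in the source may bear on it.

In a functional assay on Huh-7 cells (Homo sapiens) for antiproliferative activity, read by CCK-8 assay, with a stated time of 72 h (on this read-out lower numbers stand for stronger inhibition of growth and higher numbers for weaker inhibition of growth), compound 1 (`CC[C@@H]1C(=O)N(C)c2cnc(-n3ccc4ccccc43)nc2N1C1CCCC1`) gives 4690 nM. Among the measured compounds shown here, this is the lower of the two numbers measured so far, and the gap to the other lies beyond the usual scatter: compound 2 (`CCNC(=O)c1ccc2c(ccn2-c2ncc3c(n2)N(c2ccn(C)n2)C(CC)C(=O)N3C)c1`) gives 20300 nM.

The next molecule is compound 3 (`CCCCNC(=O)c1ccc2c(ccn2-c2ncc3c(n2)N(C2CCCC2)[C@H](CC)C(=O)N3C)c1`). It differs from compound 1 by having butylcarbamoyl in place of hydrogen on an aromatic carbon of a six-membered aromatic ring of carbon only (butylcarbamoyl in place of hydrogen on an aromatic carbon).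

For the measured compounds named here, no two measured compounds differ in just one place, so the data offer no direct guide to this change. In this assay, a small shift towards stronger growth inhibition is expected, not clearly beyond the scatter: the expected step is a 1.9-fold lower number from compound 1 to compound 3 (0.27 log units; within the scatter).

For compound 3 the estimated value is 2500 nM, with an expected range from 400 nM to 12000 nM.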

Compound 3, concentration for 50% growth inhibition: 683 nM
Compound 3: the middle estimate sits 3.7-fold (0.56 log units) above what was measured, and the stated range covers the measured number.
By their numbers in this assay, from the lowest: compound 3; then compound 1; then compound 2.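

In this assay, among the compounds shown here, placing butylcarbamoyl in place of hydrogen on an aromatic carbon gives a 6.9-fold lower number from compound 1 to compound 3 (0.84 log units; beyond the scatter), the first step in this set that changes a single place. This shows that the carbon on the six-membered aromatic ring of carbon only, meta to a fused ring and para to a fused ring, accepts a chain of this size, and that growth inhibition becomes stronger rather than weaker with it. No measurement shown here explains the shift.

On these data alone, it remains open whether the stronger inhibition belongs to the amide link, the butyl chain or both, and a carboxylic acid or a longer chain at this carbon would help separate these possibilities. A single step also cannot show whether the same change would help on a different core.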